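Methoxy to hydrogen on two cores: working notes

The source may hold more compounds than are shown below. What is called first, only, known or untested is meant among the compounds shown, and "the series" means these compounds.

Measured compounds in a functional assay on U-373MG ATCC cells (Homo sapiens) for inhibition, read by colorimetric assay and MTT assay, with a stated time of 72 h; a lower number here means a stronger inhibitor, a higher number a weaker inhibitor:

compound 1 `COc1ccc(C(=O)NNC(=S)Nc2csc(-c3ccccc3)c2)cc1`: 41000 nM
compound 2 `COc1ccc(C(=O)NNC(=S)Nc2csc(-c3ccccc3)c2)cc1OC`: 59000 nM
compound 3 `COc1ccc(-c2cc(Nc3nnc(-c4ccc(C)cc4)s3)cs2)cc1`: a limit of the assay, > 100000 nM

Among the measured compounds shown here, the only measured single-point step is hydrogen in place of methoxy on an aromatic carbon; it gives a 1.4-fold lower number from compound 2 to compound 1 (0.16 log units; within the scatter). Compound 3 carries a different core from compound 2, and the difference between the two cores is not broken down here. For compound 3 the assay reports only a limit, which is where the limit of > 100000 nM in this assay, at which 1 of the 3 values shown sits, sits.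

Compound 4 `Cc1ccc(-c2nnc(Nc3csc(-c4ccccc4)c3)s2)cc1` is not yet measured. It differs from compound 3 by hydrogen in place of methoxy on an aromatic carbon. For the measured compounds named here, this is the same kind of change as the one from compound 2 to compound 1, but the surroundings differ: in compound 2 the methoxy sits ortho to a methoxy group and meta to a large group, whereas in compound 3 it sits para to a large group. Because a 1.4-fold lower number from compound 2 to compound 1 (0.16 log units; within the scatter) is within the scatter, the expected step is a step that the limit leaves unreadable from compound 3 to compound 4, and compound 4 is expected to stay at the limit. Compound 4 is estimated at 120000 nM in this assay, between 50000 nM and 300000 nM.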

Compound 4, half-maximal inhibitory concentration: > 100000 nM
Compound 4: only a limit was reported; the forecaster's own chance of this, stated with the estimate: 70%; the middle value is on the limit's open side.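

Compound 3 and compound 4 each give only a limit of the assay in this assay, so no step between them can be read: the limit of > 100000 nM in this assay, at which 2 of the 4 values shown sit.

The compounds shown leave open whether hydrogen in place of methoxy, para to a large group, changes the number at all on the core of compound 3.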